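A few compounds are considered here, and "the series" means these few. Any claim that something is new, unique, unknown or untested is made for them only; others in the source may bear on it.

Measured compounds:
compound 1 `Clc1ccc2[nH]c(SCc3ccccc3CCc3ccccc3)nc2c1`: 47%
compound 2 `Clc1ccc2[nH]c(SCc3ccccc3CCCc3ccccc3)nc2c1`: 19%

Both numbers come from an assay on isolated protein for inhibition of Indoleamine 2,3-dioxygenase 1 (Homo sapiens), with a stated time of 60 min, tested at 10 uM; on this read-out higher numbers stand for more inhibition at the one concentration tested (going by the name of the read-out) and lower numbers for less inhibition. Compound 2 stands lowest of the two values; its nearest neighbour is compound 1, and the step of a number 28 percentage points lower from compound 1 to compound 2 (beyond the scatter) lies beyond the scatter, so the longer chain of compound 2 goes with the weaker read-out.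

Compound 3 `Clc1ccc2[nH]c(SCc3ccccc3C#Cc3ccccc3)nc2c1` is not yet measured in this assay. It differs from compound 2 in one place: 2-phenylethynyl in place of 3-phenylpropyl on an aromatic carbon

Going by the values given here, the only measured step that bears on this change is a number 28 percentage points lower from compound 1 to compound 2 (beyond the scatter), which shows that adding one saturated carbon to the link between the two aromatic rings lowered the number modestly but beyond the scatter. Compound 3 returns to a two-atom link, as in compound 1, though the link now holds a triple bond rather than saturated carbons, and the data give no measured case of that. On this basis the expected step of a number 16 percentage points higher from compound 2 to compound 3 (beyond the scatter) is upward, part of the way back toward compound 1. For compound 3 the estimate in this assay is 35%, with a range from 12% to 58%.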

Compound 3, a percentage reported as inhibition, at one concentration (the size of the read-out at that concentration, not a potency): 52%
Beside the measured number, compound 3's estimate is 17 percentage points below it; the measured number falls inside the stated range.
By their numbers in this assay, from the lowest: compound 2; then compounds 1 and 3 (each within the scatter of the next).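

In this assay, 2-phenylethynyl in place of 3-phenylpropyl on this aromatic carbon gives a number 33 percentage points higher from compound 2 to compound 3 (beyond the scatter), so the low number of compound 2 is not shared by every group carrying a terminal phenyl at this position. Set against phenethyl, the same group gives a number 5 percentage points higher from compound 1 to compound 3 (within the scatter), so in this pair a triple bond in the link cannot be told apart from the saturated link, and of the three groups at this position only 3-phenylpropyl stands apart from the other two. No measurement on these compounds bears on why the read-out follows these groups.

Still open, on these data alone, is whether a link holding an ether oxygen, an amide or an amine would keep the number of compound 1 and compound 3, and whether a longer chain ending in a triple bond would fall as 3-phenylpropyl does. Also open, as far as these compounds go, is how a fluoro or methoxy group on the terminal phenyl would act, and since each number is a read-out at a single concentration, how these compounds compare in potency.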